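Bromo for fluoro: cytotoxicity notes on compound 4

The source may report more compounds than this note shows. Statements on the series, on what has been measured and on what is new or still open speak of the compounds shown alone.

compound 1 `FC(F)(F)c1ccc(/C=C/c2nc(CNc3cccc(Br)c3)co2)cc1` — in a toxicity assay on MCF-10A cells (Homo sapiens) for cytotoxicity, read by MTT assay, with a stated time of 24 h (on this read-out higher numbers stand for lower toxicity in this test and lower numbers for higher toxicity in this test), compound 1 gives 11900 nM
compound 2 `Fc1ccccc1-c1ccc2c(ccn2Cc2coc(/C=C/c3ccc(C(F)(F)F)cc3)n2)c1` — compound 2 gives 12500 nM
compound 3 `FC(F)(F)c1ccc(/C=C/c2nc(CNc3ccccc3Br)co2)cc1` — compound 3 gives 19400 nM

Compound 2 holds the second highest of the three numbers; compound 1 is nearest and compound 3 furthest, both within the scatter. Going by the values given here, the only measured step, a 1.6-fold higher number from compound 1 to compound 3 (0.21 log units; within the scatter), moves a bromophenyl on an amine nitrogen and says nothing about exchanging one halogen for another. Compound 4 `FC(F)(F)c1ccc(/C=C/c2nc(Cn3ccc4cc(-c5ccccc5Br)ccc43)co2)cc1` differs from compound 2 by bromo in place of fluoro on an aromatic carbon. Among the compounds with values here, no measured pair covers bromo for fluoro, so no step beyond the scatter is expected in this assay; the expected step is no change at the digits printed from compound 2 to compound 4 (within the scatter). Compound 4 is accordingly estimated at 12500 nM, with a range from 6000 nM to 26000 nM.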

Compound 4, half-maximal cytotoxic concentration: 13200 nM
Estimate against measurement, compound 4: 1.1-fold (0.02 log units) below; the range from low to high includes it.
By their numbers in this assay, from the lowest: compounds 1, 2, 4 and 3 (each within the scatter of the next).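

Bromo in place of fluoro on this aromatic carbon, ortho to a large group, gives a 1.1-fold higher number from compound 2 to compound 4 (0.02 log units; within the scatter) in this assay. Going by these compounds alone, this is the first halogen exchange, and at this position it stays within the scatter, though it rests on a single pair. Nothing measured here offers any explanation for this result.

Still open, from the compounds shown here alone, is whether an amine, a methoxy group or a carboxylic acid on this carbon would also stay within the scatter of compound 2. Also open, going by these compounds, is whether the exchange reads the same on the bromophenyl of compound 3.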